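The source may report more compounds than this note shows. Statements on the series, on what has been measured and on what is new or still open speak of the compounds shown alone.

Measured so far:
- compound 1, `Clc1ccc(-c2cc(-c3ccco3)nc(-c3cccs3)c2)o1`: in a functional assay on HCT-15 cells (Homo sapiens) for cytotoxicity, in the presence of a further agent that is not named here (a higher number here means a weaker inhibitor, a lower number a stronger inhibitor), compound 1 gives > 50000 nM, which is a limit of the assay and not a number.
- compound 2, `Cc1ccc(-c2cc(-c3ccc(Cl)o3)cc(-c3cccs3)n2)cc1`: in this assay compound 2 gives 9890 nM.

Compound 2 thus stands alone with a true number; the other value is the limit of > 50000 nM in this assay, at which 1 of the 2 values shown sits. For the measured compounds named here, the single measured step, an at least 5.0-fold lower number from compound 1 to compound 2 (0.70 log units; beyond the scatter), replaces one whole ring on the shared core with another, and it makes compound 2 the stronger inhibitor of the pair, though it starts from a limit rather than a number.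

Compound 3, `Clc1ccc(-c2cc(-c3ccc(Cl)o3)cc(-c3cccs3)n2)cc1`, is not yet measured. It differs from compound 2 only in a small way: chloro in place of methyl on an aromatic carbon. Going by the values given here, no measured step touches this position, and the one step that is known changes a different part of the molecule, a whole ring rather than a single atom on a ring. It gives little guidance here. The expected step is therefore a 1.2-fold lower number from compound 2 to compound 3 (0.09 log units; within the scatter), that is, nothing beyond the scatter. Compound 3 is estimated to give about 8000 nM, with a likely range from 3000 nM to 25000 nM.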

Compound 3, half-maximal inhibitory concentration: 14200 nM
Estimate against measurement, compound 3: 1.8-fold (0.25 log units) below; the measured number falls inside the stated range.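

At the position para to a large group on the six-membered aromatic ring, chloro in place of methyl gives a 1.4-fold higher number from compound 2 to compound 3 (0.16 log units; within the scatter) in this assay, so 4-methylphenyl and 4-chlorophenyl cannot be told apart here. Replacing furan-2-yl with 4-chlorophenyl also gives an at least 3.5-fold lower number from compound 1 to compound 3 (0.54 log units; beyond the scatter), so the difference from compound 1 first seen with 4-methylphenyl does not depend on the methyl group alone. Like the step to compound 2, this step starts from the value of compound 1, which is a limit and not a number, so its true size stays unknown: the limit of > 50000 nM in this assay, at which 1 of the 3 values shown sits.

Going by these compounds, only methyl and chloro appear at this position, so it remains open whether a different kind of group there, such as an amine, a carboxylic acid or a longer chain, would shift the number beyond the scatter. On these data alone, the other rings on the shared core are the same in all three compounds, so it is also open how much each of them contributes.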